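This account rests on a few compounds, and the source may have more. Where it says the series, first, only, none or still open, it means among the compounds named here.

Measured compounds, in a functional assay on PANC-1 cells (Homo sapiens) for inhibition, read by MTT assay, with a stated time of 24 h, tested at 10 uM; a higher number here means more inhibition at the concentration tested (going by the name of the read-out), a lower number less inhibition:

compound 1 `CCOc1cc(=O)n(CCCO)c2c1CC(CC=C(C)C)C(C)(C)C2`: 16.6%
compound 2 `CCOc1cc(=O)n(CCCO)c2c1CC(C/C=C(\C)CCC=C(C)C)C(C)(C)C2`: 0.8%
compound 3 `CC(C)=CCC/C(C)=C/CC1Cc2c(OCCCNS(=O)(=O)c3ccc(Cl)cc3)cc(=O)n(CCCO)c2CC1(C)C`: 16.1%

Compound 2 stands lowest of the three: the step of a number 15.8 percentage points lower from compound 1 to compound 2 (beyond the scatter) and the step of a number 15.3 percentage points higher from compound 2 to compound 3 (beyond the scatter) both lie beyond the scatter. Compound 4 `CC(C)=CCC/C(C)=C/CC1Cc2c(OC(=O)Nc3ccccc3F)cc(=O)n(CCCO)c2CC1(C)C` differs from compound 2 as follows: (2-fluorophenyl)carbamoyl in place of ethyl on an oxygen on an aromatic ring. Within the data shown here, no measured step alters the ethyl on that oxygen. Among the measured compounds shown here, the closest precedent is the step of a number 15.3 percentage points higher from compound 2 to compound 3 (beyond the scatter), which adds a larger group two bonds along the chain from the same oxygen and raised the read-out modestly. A modest rise of similar size, and no more, is therefore expected as a number 13.2 percentage points higher from compound 2 to compound 4 (beyond the scatter). Compound 4 is estimated at 14%, with a range of 2% to 30%.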

Compound 4, a percentage reported as inhibition, at one concentration (the size of the read-out at that concentration, not a potency): 0%
Beside the measured number, compound 4's estimate is 14 percentage points above it, outside the stated range (below it).
By their numbers in this assay, from the lowest: compounds 4 and 2 (each within the scatter of the next); then compounds 3 and 1 (each within the scatter of the next).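

In this assay, (2-fluorophenyl)carbamoyl in place of ethyl on this oxygen gives a number 0.8 percentage points lower from compound 2 to compound 4 (within the scatter), so a group of 10 heavy atoms with an aromatic ring is taken here without a change in the read-out. Size alone at this oxygen therefore does not reproduce a number 15.3 percentage points higher from compound 2 to compound 3 (beyond the scatter). Nothing available explains this outcome.

Open, as far as these compounds go, is whether an unsubstituted phenylcarbamoyl, or an amine or carboxylic acid at the end of a longer chain on this oxygen, would move the read-out.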